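The compounds below may be only part of what the source reports. "The series", "measured", "known", "first", "only" and "open" are said of these compounds alone.

Of the compounds shown here, three built on one shared core have been measured in an assay on isolated protein for inhibition of adenosine deaminase (Bos taurus), with a stated time of 5 min; on this read-out lower numbers stand for stronger inhibition and higher numbers for weaker inhibition. Compound 1 `C[C@H](O)[C@@H](CCc1ccc(C(F)(F)F)cc1)n1cnc2c(N)ncnc21` gives 5.2 nM. Compound 2 `C[C@H](O)[C@@H](CCc1cccc(Br)c1)n1cnc2c(N)ncnc21` gives 0.6 nM. Compound 3 `C[C@H](O)[C@@H](CCc1cccc(-c2nccs2)c1)n1cnc2c(N)ncnc21` gives 2.6 nM. On these numbers compound 3 stands second highest of the three; its nearest neighbour is compound 1, whose number sits within the scatter of it, while compound 2 lies furthest, the gap being the measured step of a 4.3-fold higher number from compound 2 to compound 3 (0.64 log units; beyond the scatter). Within the data shown here, that step, a 1,3-thiazol-2-yl in place of bromo on the aromatic ring, is the only measured change at this position, and it was modest in size.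

Compound 4 `C[C@H](O)[C@@H](CCc1cccc(C(N)=O)c1)n1cnc2c(N)ncnc21` has not yet been measured. It differs from compound 3 in one place: carbamoyl in place of 1,3-thiazol-2-yl on an aromatic carbon, sitting meta to a large group. Among the measured compounds shown here, no measured step involves a carbamoyl, so the bearing of the earlier step is indirect: it shows only that exchanging the group on this aromatic carbon has so far shifted the number by a modest amount. A similar modest step upward is therefore expected here, a 1.9-fold higher number from compound 3 to compound 4 (0.28 log units; within the scatter), close to the edge of the scatter. The expected value for compound 4 is 5 nM, with a range from 1.5 nM to 15 nM.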

Compound 4, inhibition constant: 2.9 nM
Compound 4: middle estimate off by 1.7-fold (0.24 log units), on the high side, within the range that was stated.
By their numbers in this assay, from the lowest: compound 2; then compounds 3, 4 and 1 (each within the scatter of the next).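

In this assay, carbamoyl in place of 1,3-thiazol-2-yl leaves the number within the scatter (a 1.1-fold higher number from compound 3 to compound 4 (0.05 log units; within the scatter)), even though the two groups are quite unlike: one is a five-membered aromatic ring with 2 hetero atoms, while the other has no ring and carries 1 hydrogen-bond donor. Carbamoyl in place of bromo gives a modest step beyond the scatter (a 4.8-fold higher number from compound 2 to compound 4 (0.68 log units; beyond the scatter)), and 1,3-thiazol-2-yl in place of bromo does the same (a 4.3-fold higher number from compound 2 to compound 3 (0.64 log units; beyond the scatter)), so among the three groups seen on this aromatic carbon, bromo alone stands apart, with the lowest number. No measurement shown here explains why these two replacements cannot be told apart or why bromo differs from both.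

The compounds shown leave open whether other groups on this carbon, such as a carboxylic acid, an aminomethyl group or a nitrile, would fall in with compound 3 and compound 4 or with compound 2. They also leave open whether chloro or methyl would match bromo, and so whether its lower number belongs to bromo alone.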